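Carbonyl substituent changes on the shared bicyclic amine core

This account rests on a few compounds, and the source may have more. Where it says the series, first, only, none or still open, it means among the compounds named here.

Three amides of the same core have been measured. Compound 1 `C[C@@H]1C[C@H]1C(=O)N1CC2CNCC2C1` gives 14000 nM in an assay on CHO cells for agonist activity at Neuronal acetylcholine receptor; alpha3/beta4 (Homo sapiens), read by FLIPR and calcium flux; a higher number here means that more compound is needed for the effect, a lower number that less compound is needed. Compound 2 `CC(=O)N1CC2CNCC2C1` gives 23000 nM, and compound 3 `CCC(=O)N1CC2CNCC2C1` gives 18000 nM. Compound 3 has the second highest of the three numbers; its neighbours on either side are within the scatter of it, so no order among the three can be stated. The steps between them, a 1.3-fold higher number from compound 1 to compound 3 (0.11 log units; within the scatter) and a 1.3-fold lower number from compound 2 to compound 3 (0.11 log units; within the scatter), are both within the scatter, as is a 1.6-fold higher number from compound 1 to compound 2 (0.22 log units; within the scatter).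

Compound 4 `COC(=O)N1CC2CNCC2C1` is the next member, not yet measured. The change from compound 3 is methoxy in place of ethyl on a carbonyl carbon. The two steps that bear on it, the exchange of one carbonyl substituent for another in a 1.3-fold higher number from compound 1 to compound 3 (0.11 log units; within the scatter) and a 1.3-fold lower number from compound 2 to compound 3 (0.11 log units; within the scatter), moved nothing beyond the scatter, so for compound 4 no step beyond the scatter is expected in this assay, in either direction, and the estimated step is a 1.1-fold higher number from compound 3 to compound 4 (0.02 log units; within the scatter). Compound 4 is therefore expected at about 19000 nM, in the range 7000 nM to 55000 nM.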

Compound 4, half-maximal effective concentration: 16000 nM
Compound 4: the middle estimate sits 1.2-fold (0.07 log units) above what was measured; low and high end bracket the measured number.
By their numbers in this assay, from the lowest: compounds 1, 4, 3 and 2 (each within the scatter of the next).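

The methoxy group brings an oxygen onto the carbonyl carbon, turning propanoyl into methoxycarbonyl, and in this assay this change stays within the scatter (a 1.1-fold lower number from compound 3 to compound 4 (0.05 log units; within the scatter)). The same holds when compound 4 is set against the other two amides (a 1.4-fold lower number from compound 2 to compound 4 (0.16 log units; within the scatter)) and (a 1.1-fold higher number from compound 1 to compound 4 (0.06 log units; within the scatter)), so at this place methoxy, with 1 hydrogen-bond acceptor where ethyl has 0, goes with no readable change. No measurement at hand accounts for this flat result.

The four carbonyl substituents shown leave open whether any group at this place can move the number beyond the scatter. A longer chain, a phenyl ring or an amine on the carbonyl carbon would put that question to the shared core.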